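Swapping ethyl for 2-cyanophenyl on the amide carbonyl

The source may report more compounds than this note shows. Statements on the series, on what has been measured and on what is new or still open speak of the compounds shown alone.

Measured so far:
compound 1 `Cc1ccccc1C(=O)Nc1ncc(-c2ccccc2)n1C` — > 100000 nM (a limit of the assay)
compound 2 `CCC(=O)Nc1ncc(-c2ccc(OC)cc2)n1C` — > 100000 nM (a limit of the assay)
compound 3 `O=C(Nc1ncc(-c2ccccc2)o1)c1ccc(F)cc1` — 17000 nM

In a toxicity assay on THP-1 cells (Homo sapiens) for inhibition (on this read-out higher numbers stand for lower toxicity in this test and lower numbers for higher toxicity in this test), compound 2 reaches only a limit of the assay, > 100000 nM. Compound 1 sits at the same limit with > 100000 nM. Among the compounds with values here, compound 3 is the only one with a number, 17000 nM. Compound 2 thus stands at the limit of > 100000 nM in this assay, at which 2 of the 3 values shown sit, and its standing is known only as that limit.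

Compound 4 `COc1ccc(-c2cnc(NC(=O)c3ccccc3C#N)n2C)cc1` is still to be measured. It differs from compound 2 by 2-cyanophenyl in place of ethyl on a carbonyl carbon. Within the data shown here, no step between two measured compounds is available to size this change. The expected step is an at least 1.1-fold lower number from compound 2 to compound 4 (0.04 log units; that floor lies within the scatter), none beyond the scatter. Compound 4 is estimated at 90000 nM, with a range from 30000 nM to 200000 nM.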

Compound 4, half-maximal cytotoxic concentration: > 100000 nM
Compound 4: no number, only a limit; the forecaster's own chance of this, stated with the estimate: 60%; at least 1.1-fold (0.04 log units) between middle value and limit.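

Within the data shown here, compound 2 and compound 4 both give only a limit of the assay, so no step between them can be read. The compounds shown leave open how far 2-cyanophenyl in place of ethyl on a carbonyl carbon shifts the half-maximal cytotoxic concentration.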